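Working notes: a second chloro group on compound 3

This account rests on a few compounds, and the source may have more. Where it says the series, first, only, none or still open, it means among the compounds named here.

Measured so far in an ADME assay on HepG2 cells (Homo sapiens) for cytotoxicity, read by luminescence, with a stated time of 72 h (on this read-out higher numbers stand for an effect only at larger amounts of compound and lower numbers for an effect already at smaller amounts), for three compounds:
Compound 1 `CCOC(=O)c1c(-c2cccc(-c3ccccc3)c2)[nH]c2cc(OC)ccc2c1=O` gives > 21500 nM as a limit
Compound 2 `CCOC(=O)c1c(-c2cccc(-c3ccccc3)c2)[nH]c2cc(OC(C)C)ccc2c1=O` gives > 21500 nM as a limit
Compound 3 `CCOC(=O)c1c(-c2cccc(-c3ccccc3)c2)[nH]c2cc(Cl)ccc2c1=O` gives > 21500 nM as a limit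

Compound 3 stands at the limit of > 21500 nM in this assay, at which 3 of the 3 values shown sit, and has no number of its own. Compound 4 `CCOC(=O)c1c(-c2cccc(-c3ccccc3)c2)[nH]c2cc(Cl)c(Cl)cc2c1=O` differs from compound 3 by chloro in place of hydrogen on an aromatic carbon as chloro in place of hydrogen on an aromatic carbon, ortho to a chloro group. For the measured compounds named here, the steps that bear on it are a step that the two limits leave unreadable from compound 1 to compound 3 and a step that the two limits leave unreadable from compound 2 to compound 3 and also a step that the two limits leave unreadable from compound 1 to compound 2 and none has a readable size. No step beyond the scatter is therefore expected in this assay in either direction. The expected outcome is a step that the limit leaves unreadable from compound 3 to compound 4 on this estimate. For compound 4 the estimate is 25000 nM with an expected range from 10000 nM to 50000 nM in this read-out.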

Compound 4, half-maximal effective concentration: > 21500 nM
Compound 4: a limit, no number; the forecaster's own chance of this, stated with the estimate: 75%; the middle value is on the limit's open side.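

In this assay, compound 3 and compound 4 both give only a limit, so no step can be read between them: the limit of > 21500 nM in this assay, at which 4 of the 4 values shown sit.

The compounds shown leave open whether chloro in place of hydrogen changes this read-out, and at what concentration any of the four shows an effect.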